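Trimethoxyphenyl pyrazole chalcones: cytotoxicity at a single dose

A few compounds are considered here, and "the series" means these few. Any claim that something is new, unique, unknown or untested is made for them only; others in the source may bear on it.

Measured so far:
compound 1 `COc1cc(-c2cc(/C=C/C(=O)c3ccc(N)cc3)[nH]n2)cc(OC)c1OC` — 93%
compound 2 `COc1cc(-c2cc(/C=C/C(=O)c3ccc(Cl)c(Cl)c3)[nH]n2)cc(OC)c1OC` — 96%

In a functional assay on UACC-257 cells (Homo sapiens) for cytotoxicity, read by sulforhodamine B assay, with a stated time of 48 h, tested at 0.1 uM (a higher number here means a weaker effect of the compound at the concentration tested, a lower number a stronger effect), compound 1 gives 93%, the lowest of the two numbers, with compound 2 nearest at 96%; the step of a number 3 percentage points higher from compound 1 to compound 2 (within the scatter) is within the scatter, so the two compounds cannot be told apart here.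

Compound 3 `COc1cc(-c2cc(/C=C/C(=O)c3ccc(F)c(F)c3)[nH]n2)cc(OC)c1OC` is not yet measured. It differs from compound 1 as follows: 3,4-difluorophenyl in place of 4-aminophenyl on a carbonyl carbon. Going by the values given here, the only measured step that bears on this change is the one from compound 1 to compound 2, where a halogenated aryl group likewise replaced the 4-aminophenyl on the carbonyl carbon, and that step was a number 3 percentage points higher from compound 1 to compound 2 (within the scatter). On that basis no step beyond the scatter is expected in this assay. The expected step of a number 1 percentage points higher from compound 1 to compound 3 (within the scatter) is accordingly small. Compound 3 is estimated at 94%, with a range from 85% to 103%.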

Compound 3, a percentage reported as activity, at one concentration (the size of the read-out at that concentration, not a potency): 92%
For compound 3 the middle estimate is 2 percentage points above the measured one, within the range that was stated.
By their numbers in this assay, from the lowest: compounds 3, 1 and 2 (each within the scatter of the next).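

In this assay, replacing 4-aminophenyl on the carbonyl carbon with 3,4-difluorophenyl gives a number 1 percentage points lower from compound 1 to compound 3 (within the scatter), so a second halogenated aryl group leaves the read-out where the first one did. The counts also change here, from 1 hydrogen-bond donor and 1 hydrogen-bond acceptor in 4-aminophenyl to 0 of each in 3,4-difluorophenyl, with no step beyond the scatter. Fluorine in place of chlorine on the same aryl group gives a number 4 percentage points lower from compound 2 to compound 3 (within the scatter), so this change does not separate the two halogenated compounds at this single concentration, and no measured evidence bears on the reason.

The compounds shown leave open whether a carboxylic acid or a longer alkyl chain on the carbonyl carbon would give a step beyond the scatter. They also leave open whether compound 1, compound 2 and compound 3 would separate at another concentration.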